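A few compounds are considered here, and "the series" means these few. Any claim that something is new, unique, unknown or untested is made for them only; others in the source may bear on it.

Compound 1 `CC(C)c1c(C(=O)NCc2ccccc2)nn(-c2ccc(F)cc2)c1OC[C@@H](O)C[C@@H](O)CC(=O)O` is the reference point of this small series. In an assay on microsomes from liver for inhibition of 3-hydroxy-3-methylglutaryl-coenzyme A reductase (Rattus norvegicus) (on this read-out lower numbers stand for stronger inhibition and higher numbers for weaker inhibition), compound 1 gives 3.8 nM, the lowest of the three numbers recorded. Compound 2 `CC(C)c1c(C(=O)N2CCC[C@H](c3ccccc3)C2)nn(-c2ccc(F)cc2)c1OC[C@@H](O)C[C@@H](O)CC(=O)O` gives 4.8 nM in this assay, and compound 3 `CC(C)c1c(C(=O)NCc2ccccc2Cl)nn(-c2ccc(F)cc2)c1OC[C@@H](O)C[C@@H](O)CC(=O)O` gives 9.5 nM.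

Compound 4 `CC(C)c1c(C(=O)N(C)Cc2cccc(F)c2)nn(-c2ccc(F)cc2)c1OC[C@@H](O)C[C@@H](O)CC(=O)O` has not yet been measured. It differs from compound 1 in one place: (3-fluorobenzyl)(methyl)amino in place of benzylamino on a carbonyl carbon. Two of the measured steps bear on this change. Replacing the hydrogen-bond donor of the amide by a ring-closed amine, a 1.3-fold higher number from compound 1 to compound 2 (0.10 log units; within the scatter), stayed within the scatter. Adding a halogen to the aromatic ring of the benzyl group, a 2.5-fold higher number from compound 1 to compound 3 (0.40 log units; beyond the scatter), gave a modest rise in the number. Compound 4 carries both kinds of alteration at once, a methyl on the nitrogen and a fluorine on the ring, so a step comparable to that seen from compound 1 to compound 3 is expected, upward in the number, and a 1.8-fold higher number from compound 1 to compound 4 (0.27 log units; within the scatter) is the estimate. For compound 4 the expected value in this assay is 7 nM, within a range from 3 nM to 16 nM.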

Compound 4, half-maximal inhibitory concentration: 14 nM
Compound 4: the middle estimate sits 2.0-fold (0.30 log units) below what was measured, within the range that was stated.
By their numbers in this assay, from the lowest: compounds 1, 2, 3 and 4 (each within the scatter of the next, the first and the last beyond it).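

In this assay, the change to (3-fluorobenzyl)(methyl)amino on the carbonyl carbon, which removes the hydrogen-bond donor of benzylamino, gives a 3.7-fold higher number from compound 1 to compound 4 (0.57 log units; beyond the scatter) and so lies beyond the scatter. Losing that donor therefore does not leave the number unchanged in every setting: compound 2 also lacks it and stays within the scatter of compound 1, yet a 2.9-fold higher number from compound 2 to compound 4 (0.46 log units; beyond the scatter) is a step beyond the scatter. The two halogen-bearing benzyl compounds show no separation, with a 1.5-fold higher number from compound 3 to compound 4 (0.17 log units; within the scatter) remaining within the scatter.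

No measurement shown accounts for these steps. The compounds leave open how the step divides between the methyl and the fluorine, and how an amine or a carboxylic acid on the benzyl ring would read in this assay at this place.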